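A few compounds are considered here, and "the series" means these few. Any claim that something is new, unique, unknown or untested is made for them only; others in the source may bear on it.

Compound 1 `CCCOc1ccc(C(O)C2OC(=O)c3c(OC)cc(OC)cc32)cc1` carries a propoxy group on its outer ring. In a functional assay on RAW264.7 cells (Mus musculus) for inhibition, read by Griess assay, with stated times of 1 h and 24 h (a lower number here means a stronger inhibitor, a higher number a weaker inhibitor), compound 1 gives 9260 nM, the higher of the two plain numbers measured here. Going by the values given here, compound 2 `COCCCOc1ccc(C(O)C2OC(=O)c3c(OC)cc(OC)cc32)cc1` gives 1260 nM, and the step of a 7.3-fold lower number from compound 1 to compound 2 (0.87 log units; beyond the scatter) is the only change that moved the number beyond the usual scatter. Compound 3 `COc1cc(OC)c2c(c1)C(C(O)c1ccc(OCc3ccccc3)cc1)OC2=O` reaches only a limit of the assay, > 10000 nM, which is the limit of > 10000 nM in this assay, at which 1 of the 3 values shown sits. The step of an at least 1.0-fold higher number from compound 1 to compound 3 (0.03 log units; that floor lies within the scatter) can therefore only be bounded, and the step of an at least 7.9-fold higher number from compound 2 to compound 3 (0.89 log units; beyond the scatter) runs opposite to the gain seen with compound 2.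

Compound 4 `COc1cc(OC)c2c(c1)C(C(O)c1ccc(OCc3ccc(Cl)cc3)cc1)OC2=O` differs from compound 1 by 4-chlorophenyl in place of ethyl on a saturated chain carbon bound to an oxygen on an aromatic ring. This closely resembles the change from compound 1 to compound 3, where a phenyl entered at the same place and the result was a limit. Compound 4 is therefore expected to be a weak inhibitor, and the step of a 1.6-fold higher number from compound 1 to compound 4 (0.21 log units; within the scatter) is estimated to run toward a higher number, with a fair chance that only a limit is reported. For compound 4 the estimate is 15000 nM, expected to lie between 6000 nM and 40000 nM.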

Compound 4, half-maximal inhibitory concentration: 4320 nM
Compound 4: the middle estimate sits 3.5-fold (0.54 log units) above what was measured; measured number outside the range, below it.
By their numbers in this assay, from the lowest: compound 2; then compound 4; then compound 1. At a limit, above all of these: compound 3.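

In this assay, a ring at this place can go with stronger inhibition than the propoxy group gives, as shown by a 2.1-fold lower number from compound 1 to compound 4 (0.33 log units; beyond the scatter), yet the methoxy-bearing chain stays ahead, with a 3.4-fold higher number from compound 2 to compound 4 (0.54 log units; beyond the scatter). What separates the two ring-bearing compounds is a single chloro on an aromatic carbon, with an at least 2.3-fold lower number from compound 3 to compound 4 (0.36 log units; beyond the scatter). Compound 3 stands at a limit, so the size of this step is only a floor: the limit of > 10000 nM in this assay, at which 1 of the 4 values shown sits.

From the compounds shown here alone, whether bromo, methoxy or nitrile could replace the chloro with the same result remains open. So does whether an amine in place of the methoxy on the chain of compound 2 would keep its inhibition.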